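The compounds below may be only part of what the source reports. "The series", "measured", "known", "first", "only" and "open" are said of these compounds alone.

Compound 1 `CCC(C)c1cc(C)c(C(=O)N=C(N)N)cc1S(C)(=O)=O`: 8 nM
Compound 2 `Cc1cc(C2CCC2)c(S(C)(=O)=O)cc1C(=O)N=C(N)N`: 8.2 nM
Compound 3 `Cc1cc(OC2CCCC2)c(S(C)(=O)=O)cc1C(=O)N=C(N)N`: 27 nM

All three share one core and were tested in a functional assay for inhibition of sodium/hydrogen exchanger (Oryctolagus cuniculus); on this read-out lower numbers stand for stronger inhibition and higher numbers for weaker inhibition. In this assay compound 1 gives 8 nM and compound 2 gives 8.2 nM; the step of a 1.0-fold higher number from compound 1 to compound 2 (0.01 log units; within the scatter) lies within the scatter, so these two cannot be ordered. Compound 3 gives 27 nM, the highest number of the three, and the steps of a 3.4-fold higher number from compound 1 to compound 3 (0.53 log units; beyond the scatter) and a 3.3-fold higher number from compound 2 to compound 3 (0.52 log units; beyond the scatter) are both modest yet beyond the scatter.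

Compound 4 `Cc1cc(N)c(S(C)(=O)=O)cc1C(=O)N=C(N)N` is not yet measured. It differs from compound 3 in one place: amino in place of cyclopentyloxy on an aromatic carbon. For the measured compounds named here, none of the measured steps swaps a group for amino at this position, so no step bears on it directly. What the measured steps do show is that exchanging the group at this position has so far moved the numbers by modest amounts only, and that the two carbon-only groups in compound 1 and compound 2 gave lower numbers than the cyclopentyloxy group in compound 3. Compound 4 is therefore expected to show a modest step upward, a 2.2-fold higher number from compound 3 to compound 4 (0.35 log units; beyond the scatter), rather than a large jump. The estimate for compound 4 in this assay is 60 nM, with a range from 15 nM to 250 nM.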

Compound 4, half-maximal inhibitory concentration: 16 nM
Compound 4: middle estimate off by 3.8-fold (0.57 log units), on the high side; measured number inside the range.
By their numbers in this assay, from the lowest: compounds 1, 2, 4 and 3 (each within the scatter of the next, the first and the last beyond it).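

In this assay the exchange of cyclopentyloxy, with its five-membered ring of carbon only, for amino, a single nitrogen that brings a hydrogen-bond donor, gives a 1.7-fold lower number from compound 3 to compound 4 (0.23 log units; within the scatter) and so leaves these two compounds unordered. The comparisons with the carbon-only groups, a 2.0-fold higher number from compound 2 to compound 4 (0.29 log units; within the scatter) and a 2.0-fold higher number from compound 1 to compound 4 (0.30 log units; within the scatter), also stay inside the scatter, so compound 4 cannot be ordered against any of the other three, even though compound 3 stands apart from compound 1 and compound 2; the position ortho to a methylsulfonyl group thus holds a group as small as amino, as well as the larger sec-butyl, cyclobutyl and cyclopentyloxy groups, with no large change in the number. Nothing available here explains how amino comes to sit in this range.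

The compounds shown leave open whether a substituted amine such as dimethylamino, or a small ether such as methoxy, would stay in the same range. They also leave open what a carboxylic acid at this position would do, since every group so far carries no net charge.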